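The compounds below may be only part of what the source reports. "The series", "measured", "known", "first", "only" and "open" are said of these compounds alone.

Measured compounds and their values:

- Compound 1, `CC(C)Cc1ccc(C(C)c2n[nH]c(=S)n2N)cc1`: 16200 nM
- Compound 2, `COc1ccc(C2=Nn3c(nnc3C(C)c3ccc(-c4ccccc4)c(F)c3)SC2)cc1`: 5800 nM
- Compound 3, `CC(c1ccc(-c2ccccc2)c(F)c1)c1nnc2n1N=C(c1ccc(Br)cc1)CS2`: 6200 nM

In a functional assay on Mahlavu cells (Homo sapiens) for inhibition, read by sulforhodamine B assay, with a stated time of 72 h (a higher number here means a weaker inhibitor, a lower number a stronger inhibitor), compound 3 gives 6200 nM. Among the three measured compounds this number stands second highest: the nearest is compound 2, with its value within the scatter of compound 3, and the furthest is compound 1, whose value lies beyond the scatter on the higher side.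

Compound 4, `CC(c1ccc(-c2ccccc2)c(F)c1)c1nnc2n1N=C(c1ccc([N+](=O)[O-])cc1)CS2`, is not yet measured in this assay. It differs from compound 3 by nitro in place of bromo on an aromatic carbon.

Going by the values given here, only one measured step bears on this change, and only loosely: the step of a 1.1-fold higher number from compound 2 to compound 3 (0.03 log units; within the scatter), which exchanged one group for another at what appears to be the same aromatic carbon and left the number essentially where it was. Among the compounds with values here, no step in the set involves a nitro group, so there is nothing to suggest that this exchange should move the number much in either direction. The expectation for compound 4 is therefore a step of about a 1.0-fold lower number from compound 3 to compound 4 (0.01 log units; within the scatter), that is, none beyond the scatter. On that basis compound 4 is estimated to give 6000 nM in this assay, with a range from 3000 nM to 12000 nM.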

Compound 4, half-maximal inhibitory concentration: 9400 nM
Compound 4: middle estimate off by 1.6-fold (0.19 log units), on the low side; the measured number falls inside the stated range.
By their numbers in this assay, from the lowest: compounds 2, 3, 4 and 1 (each within the scatter of the next, the first and the last beyond it).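

In this assay, replacing the 4-bromophenyl with the 4-nitrophenyl gives (a 1.5-fold higher number from compound 3 to compound 4 (0.18 log units; within the scatter)), and the comparison with the methoxy group gives (a 1.6-fold higher number from compound 2 to compound 4 (0.21 log units; within the scatter)); both steps lie within the scatter. Methoxy, bromo and nitro have now all been read at this one position on the shared core, and all three values lie within the scatter of one another, a result that the single comparison of methoxy with bromo could not show. Nitro brings more heavy atoms than bromo as well as hydrogen-bond acceptors, yet this exchange did not carry the number beyond the scatter, and nothing available explains why these groups read alike.

The compounds shown leave open whether this position stays as undemanding with a different kind of group, such as an amine, a carboxylic acid or a longer chain in place of the nitro. Compounds 2, 3 and 4 also all carry the same fluoro group, so they cannot show whether the same exchanges would read alike without it.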